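The source may hold more compounds than are shown below. What is called first, only, known or untested is meant among the compounds shown, and "the series" means these compounds.

For the measured compounds named here, compound 2, `CC(C)(C)[C@H](N)CN(C(=O)[C@@H]1C[C@H]1c1ccccc1)c1ccc(-c2ccccc2)cc1`, stands at the low end of the numbers recorded so far in a functional assay for agonist activity at G protein-coupled receptor 88 (Homo sapiens), read by HTRF and cAMP accumulation; on this read-out lower numbers stand for an effect already at smaller amounts and higher numbers for an effect only at larger amounts of compound: compound 2 gives 11 nM, the only single number for it, with one further entry that carries no number. Compound 1, `CC[C@H](C)[C@H](N)CN(C(=O)[C@@H]1C[C@H]1c1ccccc1)c1ccc(-c2ccccc2)cc1`, shares the same core and differs in the side chain; in this assay compound 1 gives 230 nM; 800 nM (2 entries), and the spread of its repeated entries, (the several entries of compound 1 in this assay, 230 nM; 800 nM (2 entries)), shows how far two measurements of one compound can lie apart. Compound 3, `O=C([C@@H]1C[C@H]1c1ccccc1)N(CCNCC1CCCCC1)c1ccc(-c2ccccc2)cc1`, has not yet been measured. It differs from compound 2 by ((cyclohexylmethyl)amino)methyl in place of 1-amino-2,2-dimethylpropyl on a saturated chain carbon bound to an amide-type nitrogen; cut one bond further out, the change reads 2-amino-3,3-dimethylbutyl to 2-((cyclohexylmethyl)amino)ethyl, so the primary amine of compound 2 becomes a secondary amine bearing a ring, and the defined stereocentre disappears. Going by the values given here, no measured pair covers such a change, so its size can only be estimated. Compound 3 is expected to be weaker than compound 2, by a step of a 14-fold higher number from compound 2 to compound 3 (1.13 log units; beyond the scatter) that goes beyond the usual scatter. Compound 3 is therefore estimated at 150 nM, within a range from 30 nM to 1500 nM.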

Compound 3, half-maximal effective concentration: 6.6 nM
Estimate against measurement, compound 3: 23-fold (1.36 log units) above; the whole stated range lies above it.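

In this assay, putting ((cyclohexylmethyl)amino)methyl in place of 1-amino-2,2-dimethylpropyl on a saturated chain carbon bound to an amide-type nitrogen gives a 1.7-fold lower number from compound 2 to compound 3 (0.22 log units; within the scatter) and so the two compounds cannot be told apart. The earlier compounds shown here both carried a primary amine and a defined stereocentre on this side chain, whereas this pair shows that a secondary amine bearing a six-membered non-aromatic ring of carbon only, with no defined stereocentre, can read the same as compound 2. The close agreement of the two numbers should not be over-read, since repeated entries of one compound can lie well apart: the several entries of compound 1 in this assay, 230 nM; 800 nM (2 entries).

On these data alone, this single step changes the amine, the ring and the stereocentre together, and the separate share of each stays unknown. Also open, as far as these compounds go, is how a tertiary amine, a benzylamine with a phenyl ring in place of the cyclohexyl ring, or a simple ethylamine on the same chain would read at this position.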